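The compounds below may be only part of what the source reports. "The series", "measured", "known", "first", "only" and "open" are said of these compounds alone.

Measured so far:
- compound 1 `Cc1c(Cc2c(F)cccc2F)nc(N(C)C(C)C)[nH]c1=O`: 79000 nM
- compound 2 `Cc1c(Cc2c(F)cccc2F)nc(N2CCCCC2C)[nH]c1=O`: 75000 nM

In an ADME assay on MT4 cells (Homo sapiens) for cytotoxicity, read by MTT assay, with a stated time of 4 days (a higher number here means that more compound is tolerated, a lower number that less compound is tolerated), compound 2 gives 75000 nM, and compound 1 gives 79000 nM. These two numbers lie within the scatter of each other, so the data do not rank the two compounds.

Compound 3 `Cc1c(Cc2c(F)cccc2F)nc(N2CCCC(C)C2)[nH]c1=O` has not yet been measured. It carries 3-methylpiperidin-1-yl in place of 2-methylpiperidin-1-yl on an aromatic carbon, between two ring nitrogen atoms: 3-methylpiperidin-1-yl in place of 2-methylpiperidin-1-yl on an aromatic carbon. The two compounds have the same atoms, joined differently.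

Among the compounds with values here, only one measured step bears on this change: a 1.1-fold lower number from compound 1 to compound 2 (0.02 log units; within the scatter). Within the data shown here, that swap of 2-methylpiperidin-1-yl for isopropyl(methyl)amino is a different change, and no measured step compares the two methylpiperidinyl groups directly, so the evidence is indirect and thin. Even so, it gives no reason to expect a shift in either direction in this assay.

The expected result is no step beyond the scatter, with an estimated no change at the digits printed from compound 2 to compound 3 (within the scatter). For compound 3 the estimated value is 75000 nM, with an expected range of 38000 nM to 150000 nM.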

Compound 3, half-maximal cytotoxic concentration: > 75000 nM
Compound 3: a limit, no number; the forecaster's own chance of this, stated with the estimate: 15%; the middle value sits exactly at the limit.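

In this assay compound 3 gives > 75000 nM, which is a limit of the assay and not a number. Within the data shown here, this is the first direct comparison of the two methylpiperidinyl groups at this position, and 3-methylpiperidin-1-yl in place of 2-methylpiperidin-1-yl gives a number no lower from compound 2 to compound 3 (the limit leaves the size open), so the swap shows no loss of tolerated concentration, though a gain of any size remains unproven. The comparison has a direction but no size, and the step between the other pair involving compound 3 cannot be read at all, because of the limit itself: the limit of > 75000 nM in this assay, at which 1 of the 3 values shown sits.

On these data alone, whether compound 3 is really tolerated at higher concentrations than compound 2 stays open, since the data cannot separate a real gap from none. Also open, as far as these compounds go, is how 4-methylpiperidin-1-yl, with the methyl group moved further round the ring, or a morpholine in the same place on the shared core would read in this assay.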